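A Basic Ring in Place of a Fluorophenyl Group

The source may report more compounds than this note shows. Statements on the series, on what has been measured and on what is new or still open speak of the compounds shown alone.

Compound 1 `CN1CCC(c2ccc3c(c2)oc(=O)n3C(=O)NCCCCc2ccc(F)cc2)CC1`: 22000 nM
Compound 2 `CCCCCNC(=O)n1c(=O)oc2cc(-c3ccc(F)cc3)ccc21`: < 1000 nM

In a physicochemical assay for solubility, read by HPLC, in phosphate buffer, measured as kinetic solubility, with a stated time of 1 h, at pH 7.4, tested at 250 uM (a lower number here means a less soluble compound, a higher number a more soluble compound), compound 1 gives 22000 nM. Compound 2 gives only a limit in this assay, < 1000 nM, and therefore stands at the limit of < 1000 nM in this assay, at which 1 of the 2 values shown sits. Compound 3 `CCCCCNC(=O)n1c(=O)oc2cc(C3CCN(C)CC3)ccc21` carries 1-methylpiperidin-4-yl in place of 4-fluorophenyl on an aromatic carbon. Because compound 1, which also carries a 1-methylpiperidin-4-yl group, gives 22000 nM, the step from compound 2 to compound 3 in this assay is expected to be large and upward, well beyond the scatter, at an at least 25-fold higher number from compound 2 to compound 3 (1.39 log units; beyond the scatter). Compound 3 is thus estimated at 25000 nM, in the range 5000 nM to 120000 nM.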

Compound 3, solubility: 240000 nM
Estimate against measurement, compound 3: 9.6-fold (0.98 log units) below; the measured number lies above the stated range.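

In this assay, 1-methylpiperidin-4-yl in place of 4-fluorophenyl on this aromatic carbon gives an at least 240-fold higher number from compound 2 to compound 3 (2.38 log units; beyond the scatter), a direct reading of this change at this position. That step is only a bound, because compound 2 stands at a limit of the assay: the limit of < 1000 nM in this assay, at which 1 of the 3 values shown sits. With 1-methylpiperidin-4-yl held in place, methyl in place of 4-fluorophenyl on the saturated chain gives an 11-fold higher number from compound 1 to compound 3 (1.04 log units; beyond the scatter), so the far end of the chain also moves the number. From the compounds shown here alone, whether another amine, such as morpholine or an open-chain dimethylamino group, would give a similar number on this aromatic carbon remains open.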